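The source may report more compounds than this note shows. Statements on the series, on what has been measured and on what is new or still open speak of the compounds shown alone.

Among the compounds with values here, compound 2 `ClCc1ccccc1Cn1cnc2c(Cl)nc(Cl)nc21` and compound 1 `ClCc1ccc(Cn2cnc3c(Cl)ncnc32)cc1` are the two measured members of this small set. In a functional assay on SN12C cells (Homo sapiens) for cytotoxicity, read by sulforhodamine B assay, with a stated time of 48 h (a higher number here means a weaker inhibitor of growth, a lower number a stronger inhibitor of growth), compound 2 gives 720 nM, the lower of the two numbers on hand, while compound 1 gives 1020 nM; the gap between them lies within the usual scatter, so the two cannot be told apart. They also differ in more than one place, so no single step can be read from them. Compound 3 `ClCc1ccccc1Cn1cnc2c(Cl)ncnc21` has not yet been measured in this assay. It arises from compound 2 by one change: hydrogen in place of chloro on an aromatic carbon. Within the data shown here, no measured pair shows what removing this chloro does, so the expectation in this assay is a small step at most, if anything toward a weaker inhibitor, not clearly beyond the scatter. Compound 3 is therefore expected to give about 1000 nM, within a likely range of 400 nM to 2500 nM. That estimate means an expected step from compound 2 to compound 3 of a 1.4-fold higher number from compound 2 to compound 3 (0.14 log units; within the scatter).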

Compound 3, concentration for 50% growth inhibition: 3380 nM
Beside the measured number, compound 3's estimate is 3.4-fold (0.53 log units) below it, and the stated range ends below it.
By their numbers in this assay, from the lowest: compounds 2 and 1 (each within the scatter of the next); then compound 3.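

In this assay, within the data shown here, hydrogen in place of chloro on an aromatic carbon gives a 4.7-fold higher number from compound 2 to compound 3 (0.67 log units; beyond the scatter), and this is the first single change in the set that can be read. The earlier compounds shown here differ in more than one place and could not show this, but the pair now shows that the chloro between two ring nitrogen atoms matters for growth inhibition: without it, the compound is a weaker inhibitor. Nothing measured here speaks to the reason for this step.

From the compounds shown here alone, it remains open whether chloro is special or whether another group at this carbon, such as an amine, a methoxy group or a nitrile, would do as well. It is also unknown whether the same step would appear on the framework of compound 1, since this reading rests on one pair.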